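This account rests on a few compounds, and the source may have more. Where it says the series, first, only, none or still open, it means among the compounds named here.

Compound 1 `Cc1cc(O)c(C2=NN(c3ccc(S(N)(=O)=O)cc3)C(c3ccccc3Cl)C2)cc1Cl` gives 3340 nM in a functional assay on ACHN cells (Homo sapiens) for antiproliferative activity, with a stated time of 48 h; a lower number here means a stronger inhibitor of growth, a higher number a weaker inhibitor of growth. Among the measured compounds shown here, compound 2 `Cc1cc(O)c(C2=NN(c3ccc(S(N)(=O)=O)cc3)C(/C=C/c3ccccc3)C2)cc1Cl` gives 5270 nM in this assay and sits at the high end of the two numbers so far, its only neighbour being compound 1 with a 1.6-fold higher number from compound 1 to compound 2 (0.20 log units; within the scatter). Compound 3 `COc1ccc(C2CC(c3cc(Cl)c(C)cc3O)=NN2c2ccc(S(N)(=O)=O)cc2)cc1OC` differs from compound 2 by 3,4-dimethoxyphenyl in place of 2-phenylethenyl on a saturated ring carbon. For the measured compounds named here, the single measured step, a 1.6-fold higher number from compound 1 to compound 2 (0.20 log units; within the scatter), also exchanged the group on this saturated ring carbon and stayed within the scatter, so no move beyond the scatter is expected from compound 2 to compound 3. Compound 3 is therefore expected near 4000 nM, range 1500 nM to 11000 nM, an estimated 1.3-fold lower number from compound 2 to compound 3 (0.12 log units; within the scatter).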

Compound 3, concentration for 50% growth inhibition: 3150 nM
Compound 3: middle estimate off by 1.3-fold (0.10 log units), on the high side, within the range that was stated.
By their numbers in this assay, from the lowest: compounds 3, 1 and 2 (each within the scatter of the next).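

In this assay the change to 3,4-dimethoxyphenyl gives a 1.7-fold lower number from compound 2 to compound 3 (0.22 log units; within the scatter) and a 1.1-fold lower number from compound 1 to compound 3 (0.03 log units; within the scatter) and so no move beyond the scatter on this saturated ring carbon. The entering group adds two hydrogen-bond acceptors and has more heavy atoms than 2-phenylethenyl, yet compounds 1, 2 and 3 remain indistinguishable in this read-out. As far as these compounds go, all three groups carry a six-membered aromatic ring of carbon only, so whether a methyl group, an amine or a carboxylic acid on this carbon would move the number beyond the scatter stays open. No evidence is available that explains these results.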